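The source may hold more compounds than are shown below. What is called first, only, known or untested is meant among the compounds shown, and "the series" means these compounds.

Compound 3, `CCc1ccc(-c2cc(-c3cn([C@H]4C[C@H](OC(C)=O)[C@@H](COC(C)=O)O4)c(=O)[nH]c3=O)on2)cc1`, gives 62.8% in a functional assay on PC-3 cells (Homo sapiens) for cytotoxicity, read by sulforhodamine B assay, tested at 10 uM (on this read-out lower numbers stand for less inhibition and higher numbers for more inhibition at the one concentration tested (going by the name of the read-out)), the lowest of the three numbers measured there; compound 1, `CCCc1cc(-c2cn([C@H]3C[C@H](OC(C)=O)[C@@H](COC(C)=O)O3)c(=O)[nH]c2=O)on1`, gives 88.1%, and compound 2, `CCCCCc1cc(-c2cn([C@H]3C[C@H](OC(C)=O)[C@@H](COC(C)=O)O3)c(=O)[nH]c2=O)on1`, gives 93.9%. Compound 4, `CC(=O)OC[C@H]1O[C@@H](n2cc(-c3cc(C)no3)c(=O)[nH]c2=O)C[C@@H]1OC(C)=O`, differs from compound 3 in one place: methyl in place of 4-ethylphenyl on an aromatic carbon. Among the compounds with values here, two measured steps bear on this change. Going a number 25.3 percentage points lower from compound 1 to compound 3 (beyond the scatter), and going a number 31.1 percentage points lower from compound 2 to compound 3 (beyond the scatter), so in both cases the arrival of 4-ethylphenyl on that aromatic carbon lowered inhibition beyond the scatter, while the step of a number 5.8 percentage points higher from compound 1 to compound 2 (within the scatter) shows that the two alkyl chains were alike. Removing 4-ethylphenyl again in favour of a small alkyl group is therefore expected to raise inhibition beyond the scatter, by a number 19.2 percentage points higher from compound 3 to compound 4 (beyond the scatter). Compound 4 is thus estimated at 82%, with a range from 65% to 95%.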

Compound 4, a percentage reported as inhibition, at one concentration (the size of the read-out at that concentration, not a potency): 92.4%
Estimate against measurement, compound 4: 10.4 percentage points below; the measured number falls inside the stated range.
By their numbers in this assay, from the lowest: compound 3; then compounds 1, 4 and 2 (each within the scatter of the next).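

In this assay, methyl on this aromatic carbon recovers what 4-ethylphenyl lost, a step of a number 29.6 percentage points higher from compound 3 to compound 4 (beyond the scatter) that places it back among the alkyl compounds. The steps of a number 1.5 percentage points lower from compound 2 to compound 4 (within the scatter) and a number 4.3 percentage points higher from compound 1 to compound 4 (within the scatter) show that methyl, propyl and pentyl here cannot be told apart, so among these four compounds only the 4-ethylphenyl compound stands apart. Nothing measured here gives a reason for that gap. On these data alone, whether the loss belongs to the phenyl ring itself or to its ethyl group stays open, as does how an amine or a carboxylic acid on this carbon would read.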